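A piperidine in place of methyl on compound 1

The compounds below may be only part of what the source reports. "The series", "measured", "known", "first", "only" and "open" are said of these compounds alone.

- compound 1 `Cc1cc(-c2cc(N3C[C@H](O)[C@@H](O)C3)ccc2O)nc(N)n1`: 400 nM
- compound 2 `Nc1nc(-c2cc(N3C[C@H](O)[C@@H](O)C3)ccc2O)cc(C2CCCCC2)n1`: 800 nM
- compound 3 `Nc1nc(-c2cc(N3C[C@H](O)[C@@H](O)C3)ccc2O)cc(C2CCNCC2)n1`: > 10000 nM

Going by the values given here, in a functional assay on HCT-116 cells (Homo sapiens) for cytotoxicity, with a stated time of 48 h (on this read-out higher numbers stand for weaker inhibition of growth and lower numbers for stronger inhibition of growth), compound 1 stands at 400 nM, and the only other exact number is close: a 2.0-fold higher number from compound 1 to compound 2 (0.30 log units; within the scatter). Compound 3 gives > 10000 nM, which is a limit of the assay and not a number.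

Compound 4 `Nc1nc(-c2cc(N3C[C@H](O)[C@@H](O)C3)ccc2O)cc(C2CCCNC2)n1` is not yet measured, and it has piperidin-3-yl in place of methyl on an aromatic carbon. The nearest measured change, to piperidin-4-yl, gave an at least 25-fold higher number from compound 1 to compound 3 (1.39 log units; beyond the scatter). The same group in place of cyclohexyl gave an at least 12-fold higher number from compound 2 to compound 3 (1.09 log units; beyond the scatter). A large step towards weaker growth inhibition is therefore expected, not a step within the scatter. The expected step is an 18-fold higher number from compound 1 to compound 4 (1.24 log units; beyond the scatter). For compound 4 the estimated value is 7000 nM, with an expected range of 2000 nM to 20000 nM.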

Compound 4, concentration for 50% growth inhibition: > 10000 nM
Compound 4: no number, only a limit; the forecaster's own chance of this, stated with the estimate: 55%; at least 1.4-fold (0.15 log units) between middle value and limit.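

In this assay, the loss seen with piperidin-4-yl is not confined to that group, since piperidin-3-yl also gives an at least 25-fold higher number from compound 1 to compound 4 (1.39 log units; beyond the scatter) and an at least 12-fold higher number from compound 2 to compound 4 (1.09 log units; beyond the scatter). Compound 4 gives > 10000 nM, which is a limit and not a number. Both piperidines therefore end at the same limit: the limit of > 10000 nM in this assay, at which 2 of the 4 values shown sit.

The step between compound 3 and compound 4 cannot be read, so the two piperidines cannot be ranked. Going by these compounds, whether tetrahydropyran-4-yl, with an oxygen in place of the ring nitrogen, would stay close to compound 2 remains open.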